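Taking One Chloro Group off a Dichlorophenyl Ether

The source may hold more compounds than are shown below. What is called first, only, known or untested is meant among the compounds shown, and "the series" means these compounds.

Three compounds have been measured in a functional assay on HepG2 cells (Homo sapiens) for antiproliferative activity, read by MTT assay, with a stated time of 72 h; a lower number here means a stronger inhibitor, a higher number a weaker inhibitor:
- compound 1, `NC1=NC2(CCSCC2)N(OCCCOc2ccc(Cl)c(Cl)c2)C(N)=N1`, gives 70 nM
- compound 2, `NC1=NC2(CCSCC2)N(OCCCOc2cccc(Cl)c2)C(N)=N1`, gives 90 nM
- compound 3, `NC1=NC2(CCOCC2)N(OCCCOc2cccc(Cl)c2Cl)C(N)=N1`, gives 330 nM

Compound 1 and compound 2 share one core, and compound 3 stands on another; the difference between the two cores is not broken down here. Compound 1 and compound 2 differ only in their aromatic ring, where (hydrogen in place of chloro on an aromatic carbon). That change gave a 1.3-fold higher number from compound 1 to compound 2 (0.11 log units; within the scatter), a step that does not rise above the ordinary variation of repeated measurements.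

Compound 4, `NC1=NC2(CCOCC2)N(OCCCOc2ccccc2Cl)C(N)=N1`, has not yet been measured. It comes from compound 3 by the same kind of change: hydrogen in place of chloro on an aromatic carbon. The surroundings are not identical, though. In the measured pair the leaving chloro sat ortho to a chloro group and para to a large group, whereas in compound 3 it sits ortho to a chloro group and meta to a large group. Compound 3 also differs from compound 1 in its core, so the earlier step is only a guide, not a copy.

On that basis, the step from compound 3 to compound 4 is expected to be small, about a 1.3-fold higher number from compound 3 to compound 4 (0.10 log units; within the scatter), because the comparable change gave a 1.3-fold higher number from compound 1 to compound 2 (0.11 log units; within the scatter). Compound 4 is therefore estimated at 420 nM, with a likely range from 200 nM to 900 nM.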

Compound 4, half-maximal inhibitory concentration: 1750 nM
Compound 4: the middle estimate sits 4.2-fold (0.62 log units) below what was measured, outside the stated range (above it).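

Taking the chloro off the 2,3-dichlorophenyl group of compound 3, which leaves the 2-chlorophenyl group of compound 4, gave a 5.3-fold higher number from compound 3 to compound 4 (0.72 log units; beyond the scatter), so here the loss of that one chlorine atom made a clear difference to the compound's strength as an inhibitor. The same kind of change therefore did not carry over in size from one core to the other in this assay: the same change on two cores in this assay, a 1.3-fold higher number (0.11 log units; within the scatter) from compound 1 to compound 2 and a 5.3-fold higher number (0.72 log units; beyond the scatter) from compound 3 to compound 4, 4.1-fold (0.62 log units) apart, beyond the scatter of two such steps

This does not show that the core alone is responsible, since the two pairs also differ in where the chloro leaves from, and in compound 3 it sits ortho to a chloro group and meta to a large group, so core and place remain tangled together in these four compounds.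

The compounds shown leave open how a 2,3-dichlorophenyl group would behave on the core of compound 1, a comparison that could begin to separate the effect of the core from that of the place on the ring. They also leave open whether a fluoro or a methyl group in the place of the departing chloro would keep compound 4 closer to compound 3.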